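Phenyl to thiophen-2-yl on a tetradecyl threonine amide

A few compounds are considered here, and "the series" means these few. Any claim that something is new, unique, unknown or untested is made for them only; others in the source may bear on it.

Measured compounds:
compound 1, `CCCCCCCCNC(=O)[C@@H](NC(=O)c1cccs1)[C@@H](C)O`, 149000 nM
compound 2, `CCCCCCCCCCCCCCNC(=O)[C@@H](NC(=O)c1ccccc1)[C@@H](C)O`, 54200 nM

Both compounds were tested in a functional assay on HepG2 cells (Homo sapiens) for cytotoxicity, read by MTT assay, with a stated time of 48 h; a higher number here means a weaker inhibitor, a lower number a stronger inhibitor. Compound 1 gives 149000 nM, and compound 2 gives 54200 nM. Compound 2 therefore holds the lower of the two numbers, and its gap to compound 1 lies beyond the usual scatter of such measurements. The two compounds differ in two places at once, so their values alone do not show which part of the change carries the gap.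

Compound 3, `CCCCCCCCCCCCCCNC(=O)[C@@H](NC(=O)c1cccs1)[C@@H](C)O`, has not yet been measured in this assay. It differs from compound 2 in one place: thiophen-2-yl in place of phenyl on a carbonyl carbon. Among the measured compounds shown here, no measured pair in this set isolates this change, so the expectation rests only on compound 2 and on the size of the change, which is small. Compound 3 is expected to stay close to compound 2, with a step of a 1.1-fold higher number from compound 2 to compound 3 (0.04 log units; within the scatter) that does not clearly leave the scatter. Compound 3 is estimated at 60000 nM, within a range from 25000 nM to 150000 nM.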

Compound 3, half-maximal inhibitory concentration: 88400 nM
Compound 3: the middle estimate sits 1.5-fold (0.17 log units) below what was measured; low and high end bracket the measured number.
By their numbers in this assay, from the lowest: compounds 2, 3 and 1 (each within the scatter of the next, the first and the last beyond it).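

With the tetradecyl chain held fixed, thiophen-2-yl in place of phenyl on a carbonyl carbon gives in this assay a 1.6-fold higher number from compound 2 to compound 3 (0.21 log units; within the scatter), so this exchange of aromatic rings does not clearly separate the two compounds. With the thiophen-2-yl amide held fixed, hexyl in place of hydrogen on a saturated chain carbon, eight bonds along the chain from an amide-type nitrogen, gives a 1.7-fold lower number from compound 1 to compound 3 (0.23 log units; within the scatter), which is also no clear separation. Compound 3 thus links the other two compounds through single changes, and neither change read alone leaves the scatter.

Going by these compounds, whether an amine or a carboxylic acid on the aromatic ring, or a chain longer than tetradecyl, would produce a step beyond the scatter remains open. No measurement shown here bears on the reason for either step.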